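The source may hold more compounds than are shown below. What is called first, only, known or untested is meant among the compounds shown, and "the series" means these compounds.

Of the compounds shown here, two have so far been measured in a functional assay on the whole organism for inhibition, with Rattus norvegicus as the target; on this read-out higher numbers stand for an effect only at larger amounts of compound and lower numbers for an effect already at smaller amounts. Compound 1 `CCCCSc1nsnc1C1CN2CCC1CC2` gives 0.1 mg/kg in this assay. Compound 2 `CCCCSc1nsnc1C1CN2CCC[C@@H]1C2` is the other one, and in this assay compound 2 gives only a limit, > 3 mg/kg, not a number. That is the limit of > 3 mg/kg in this assay, at which 1 of the 2 values shown sits, and it is where compound 2 stands. Compound 3 `CCCCSc1nsnc1[C@H]1CN2CCC[C@H]1C2` has not yet been measured in this assay. It keeps every atom and bond of compound 2 and differs only in how two stereocentres are drawn: the two compounds have the same atoms and bonds; at least one stereo element is drawn with a configuration in one of them and without one in the other: 2 of 3 stereo elements differ; a stereocentre at a saturated ring carbon is drawn without a configuration in compound 2 and R in compound 3; a stereocentre at a saturated ring carbon is drawn S in compound 2 and R in compound 3. For the measured compounds named here, no measured pair here differs in a single place, so no known step can guide the size of this change. Because compound 2 sits at the limit of > 3 mg/kg in this assay, at which 1 of the 2 values shown sits, any number found for compound 3 can only mean an effect at the limit or at a smaller dose, nearer to where compound 1 lies. The expected dose for compound 3 in this assay is 1 mg/kg, within 0.1 mg/kg to 10 mg/kg, which would mean an estimated step of an at least 3.0-fold lower number from compound 2 to compound 3 (0.47 log units; beyond the scatter).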

Compound 3, dose for half-maximal effect: > 3 mg/kg
Compound 3: no number, only a limit; the forecaster's own chance of this, stated with the estimate: 35%; at least 3.0-fold (0.47 log units) between middle value and limit.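

In this assay compound 2 and compound 3 each give only a limit and not a number, so no step between them can be read: the limit of > 3 mg/kg in this assay, at which 2 of the 3 values shown sit.

Still open is the true dose for each compound and whether the configurations at the two differing stereocentres matter at all: the fact that one of compounds 2 and 3 is drawn with a defined configuration and the other without, at the place where they differ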